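Hexyl to 4-hydroxyphenyl on the chain alkene

The source may hold more compounds than are shown below. What is called first, only, known or untested is meant among the compounds shown, and "the series" means these compounds.

Measured in a functional assay on HeLa cells (Homo sapiens) for cytotoxicity, read by WST assay, with a stated time of 48 h; a lower number here means a stronger inhibitor, a higher number a weaker inhibitor:
- Compound 1 `CCCCCC/C=C/C[C@H]1C[C@@H]([C@@H](O)c2ccccc2)CO[C@@H]1c1ccccc1`: 7400 nM
- Compound 2 `COc1ccc([C@@H]2OC[C@H]([C@@H](O)c3ccc(OC)c(OC)c3)C[C@H]2C/C=C/c2ccc(OC)c(OC)c2)cc1`: 29200 nM
- Compound 3 `COc1ccc(/C=C/C[C@@H]2C[C@@H]([C@@H](O)c3ccc(OC)c(OC)c3)CO[C@H]2c2ccc(OC)c(OC)c2)cc1`: 17100 nM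

Compound 1 holds the lowest of the three numbers, and compound 3 and compound 2 both lie above it beyond the scatter. Compound 4 `Oc1ccc(/C=C/C[C@H]2C[C@@H]([C@@H](O)c3ccccc3)CO[C@@H]2c2ccccc2)cc1` keeps the core of compound 1 and differs by 4-hydroxyphenyl in place of hexyl on a double-bonded chain carbon bound to a double-bonded chain carbon. Going by the values given here, no measured pair isolates this change. Compound 3 also carries an aromatic ring on that chain and gives 17100 nM, though it differs elsewhere too, so a moderate rise in the number is expected. The expected change is a 1.8-fold higher number from compound 1 to compound 4 (0.24 log units; within the scatter). For compound 4 the estimated value is 13000 nM, with an expected range of 5500 nM to 30000 nM.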

Compound 4, half-maximal inhibitory concentration: 14400 nM
Estimate against measurement, compound 4: 1.1-fold (0.04 log units) below; the measured number falls inside the stated range.
By their numbers in this assay, from the lowest: compounds 1, 4, 3 and 2 (each within the scatter of the next, the first and the last beyond it).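

In this assay, going by these compounds alone, the replacement of hexyl by 4-hydroxyphenyl gives a 1.9-fold higher number from compound 1 to compound 4 (0.29 log units; within the scatter) on the core of compound 1, the only reading of a single change at this place. On a double-bonded chain carbon bound to a double-bonded chain carbon, an open alkyl chain and a hydroxylated aromatic ring are therefore not separated by this assay. Nothing available bears on a cause for this step.

An unsubstituted phenyl at this place would separate the ring from its hydroxyl. On these data alone, how an amine, a carboxylic acid or a chain longer than hexyl would read here stays open.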